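A few compounds are considered here, and "the series" means these few. Any claim that something is new, unique, unknown or untested is made for them only; others in the source may bear on it.

Compounds 1, 2 and 3 share one core and differ only in the group carried on an amide-type nitrogen. In an assay on isolated protein for inhibition of NEDD8-activating enzyme E1 regulatory subunit (Homo sapiens), read by Western blot, with stated times of 10 min and 30 min, tested at 25 uM (a lower number here means less inhibition, a higher number more inhibition at the concentration tested (going by the name of the read-out)), compound 1 `CCCNC(=O)c1cccc2nc(OCC)n(Cc3ccc(-c4ccccc4-c4nnn[nH]4)cc3)c12` gives 32.6%, compound 2 `CCOC(=O)CNC(=O)c1cccc2nc(OCC)n(Cc3ccc(-c4ccccc4-c4nnn[nH]4)cc3)c12` gives 46.5% and compound 3 `CCOc1nc2cccc(C(=O)N[C@H]3CC[C@H](C(=O)OC)CC3)c2n1Cc1ccc(-c2ccccc2-c2nnn[nH]2)cc1` gives 28.6%. Compound 3 has the lowest of these three numbers: its gap to compound 1 lies within the scatter, its gap to compound 2 beyond it, as the steps of a number 4 percentage points lower from compound 1 to compound 3 (within the scatter) and a number 17.9 percentage points lower from compound 2 to compound 3 (beyond the scatter) show. Compound 4 `CCOc1nc2cccc(C(=O)Nc3ccccc3)c2n1Cc1ccc(-c2ccccc2-c2nnn[nH]2)cc1` changes that same position: phenyl in place of 4-(methoxycarbonyl)cyclohexyl on an amide-type nitrogen. Both earlier steps bear on this change, one small and one modest, so a shift of no more than modest size in this assay is expected, with no clear direction. For compound 4 the estimate is 33%, between 18% and 50%, which means an expected step of a number 4.4 percentage points higher from compound 3 to compound 4 (within the scatter).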

Compound 4, a percentage reported as inhibition, at one concentration (the size of the read-out at that concentration, not a potency): 34.6%
Beside the measured number, compound 4's estimate is 1.6 percentage points below it; the measured number falls inside the stated range.
By their numbers in this assay, from the lowest: compounds 3, 1 and 4 (each within the scatter of the next); then compound 2.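

In this assay, an aromatic ring on the amide-type nitrogen gives a number that cannot be told apart from those of the two saturated groups, with a number 6 percentage points higher from compound 3 to compound 4 (within the scatter) and a number 2 percentage points higher from compound 1 to compound 4 (within the scatter). The (ethoxycarbonyl)methyl group stays apart from phenyl, with a number 11.9 percentage points lower from compound 2 to compound 4 (beyond the scatter). Nothing available gives a reason for these numbers. Still open, on these data alone, is whether a carboxylic acid or an amine on a chain at this nitrogen would give a number closer to that of compound 2 or to those of the other three compounds.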